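Biaryl amide series: cytotoxicity on aryl exchange

A few compounds are considered here, and "the series" means these few. Any claim that something is new, unique, unknown or untested is made for them only; others in the source may bear on it.

Compound 1, `CCOC(=O)CCCCCOc1cccc(CN(C(=O)c2ccc(-c3cccc4ccccc34)cc2)C(C)C)c1`. In an ADME assay on HEK293 cells (Homo sapiens) for cytotoxicity, read by CellTiter-Glo and resazurin assay, with a stated time of 72 h (on this read-out higher numbers stand for an effect only at larger amounts of compound and lower numbers for an effect already at smaller amounts), compound 1 gives > 26000 nM, which is a limit of the assay and not a number.
Compound 2, `CCOC(=O)CCCCCOc1cccc(CN(C(=O)c2ccc(-c3ccc4ccccc4c3)cc2)C(C)C)c1`. In this assay compound 2 gives > 26000 nM, again a limit rather than a number.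
Compound 3, `CCOC(=O)CCCCCOc1cccc(CN(C(=O)c2ccc(-c3ccc4[nH]ccc4c3)cc2)C(C)C)c1`. In this assay compound 3 gives > 26000 nM, also a limit.

Compound 3 therefore stands only as a limit in this assay, and the two further values shown are limits as well: all three sit together at the limit of > 26000 nM in this assay, at which 3 of the 3 values shown sit. The steps between them, a step that the two limits leave unreadable from compound 1 to compound 2, a step that the two limits leave unreadable from compound 1 to compound 3 and a step that the two limits leave unreadable from compound 2 to compound 3, cannot be read in size or direction for that reason.

Compound 4, `CCOC(=O)CCCCCOc1cccc(CN(C(=O)c2ccc(-c3ccc(Cl)c(Cl)c3)cc2)C(C)C)c1`, is not yet measured. It differs from compound 3 by 3,4-dichlorophenyl in place of 1H-indol-5-yl on an aromatic carbon. The measured steps that bear on this change are the three aryl exchanges just named; each of them is unreadable because of the limit of > 26000 nM in this assay, at which 3 of the 3 values shown sit, so they give no size and no direction to carry over. The step of a number no higher from compound 3 to compound 4 (the limit leaves the size open) is expected to stay within the scatter, with the result most likely reported again as a limit. Compound 4 is thus expected to give about 26000 nM in this assay, estimated to lie between 9000 nM and 80000 nM.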

Compound 4, half-maximal effective concentration: > 26000 nM
Compound 4 gave a limit, no number; the forecaster's own chance of this, stated with the estimate: 70%; the middle value lies on the limit itself.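

In this assay compound 4 gives > 26000 nM, again a limit and not a number. The steps from compounds 1, 2 and 3 to compound 4 cannot be read in size or direction because the values all sit together: the limit of > 26000 nM in this assay, at which 4 of the 4 values shown sit. The compounds shown leave open whether these four aryl groups differ at all in this read-out, and at what concentration any effect on these cells would appear.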